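Three Aryl Groups Tried on an Aromatic Nitrogen

This account rests on a few compounds, and the source may have more. Where it says the series, first, only, none or still open, it means among the compounds named here.

Three compounds share one core and differ only in the aryl group attached to an aromatic nitrogen. Compound 1 `Cc1cc2occ(-c3nc(-c4ccccc4)c(-c4ccccc4)n3-c3ccccc3Cl)c(=O)c2cc1Cl` carries a 2-chlorophenyl there, and in a functional assay on A549 cells (Homo sapiens) for inhibition, read by MTT assay, with a stated time of 72 h (on this read-out lower numbers stand for stronger inhibition and higher numbers for weaker inhibition), compound 1 gives 12500 nM. Compound 2 `Cc1cc2occ(-c3nc(-c4ccccc4)c(-c4ccccc4)n3-c3ccc(Cl)c(Cl)c3)c(=O)c2cc1Cl` carries a 3,4-dichlorophenyl, and in this assay compound 2 gives 6250 nM. Compound 3 `Cc1ccc(-n2c(-c3coc4cc(C)c(Cl)cc4c3=O)nc(-c3ccccc3)c2-c2ccccc2)c(C)c1` carries a 2,4-dimethylphenyl, and in this assay compound 3 gives 6250 nM. Compound 2 thus stands level with compound 3 at the digits shown, the pair of them together the lowest of the three numbers, and the step of a 2.0-fold lower number from compound 1 to compound 2 (0.30 log units; within the scatter) stays within the scatter.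

Compound 4 `Cc1ccc(-n2c(-c3coc4cc(C)c(Cl)cc4c3=O)nc(-c3ccccc3)c2-c2ccccc2)cc1` has not yet been measured. 4-methylphenyl in place of 3,4-dichlorophenyl on an aromatic nitrogen The measured steps that bear on this change are all swaps of the same aryl group: a 2.0-fold lower number from compound 1 to compound 2 (0.30 log units; within the scatter), a 2.0-fold lower number from compound 1 to compound 3 (0.30 log units; within the scatter) and no change at the digits printed from compound 2 to compound 3 (within the scatter), each within the scatter. Three different aryl groups at this position have so far given numbers that cannot be told apart, so a fourth is expected to do the same, and the expected step is a 1.1-fold higher number from compound 2 to compound 4 (0.05 log units; within the scatter), nothing beyond the scatter. Compound 4 is therefore estimated at 7000 nM, with a range from 2500 nM to 20000 nM.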

Compound 4, half-maximal inhibitory concentration: 12500 nM
For compound 4 the middle estimate is 1.8-fold (0.25 log units) below the measured one; measured number inside the range.
By their numbers in this assay, from the lowest: compounds 2, 3, 1 and 4 (each within the scatter of the next).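

Within the data shown here, compound 4 brings a fourth aryl group to this position, and its chlorine-free ring still cannot be told apart from the others: with 4-methylphenyl in place of 3,4-dichlorophenyl, there is a 2.0-fold higher number from compound 2 to compound 4 (0.30 log units; within the scatter) in this assay and no step that leaves the scatter. The smallest change so far, hydrogen in place of methyl on an aromatic carbon, gives a 2.0-fold higher number from compound 3 to compound 4 (0.30 log units; within the scatter) and so also stays within the scatter, while 4-methylphenyl in place of 2-chlorophenyl gives no change at the digits printed from compound 1 to compound 4 (within the scatter) and separates nothing either. All four aryl groups, whether they carry chlorine or methyl, therefore sit within the scatter of one another at this position, and nothing measured here offers a reason for these numbers.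

These compounds leave open whether a ring of a different kind of substituent, such as a phenyl group bearing an amine or a carboxylic acid, would move the number beyond the scatter. They also leave open whether a plain alkyl chain on the aromatic nitrogen, with no aryl ring at all, would behave like the four aryl groups.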